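Tetrazole for Oxadiazole and Canine Half-Life

This account rests on a few compounds, and the source may have more. Where it says the series, first, only, none or still open, it means among the compounds named here.

Measured so far:
Compound 1 `Cc1noc(-c2c(F)cccc2-c2ccc([C@@H](C)Nc3nccc(Cl)c3NC(=O)CC#N)cc2)n1`: 2.1 h
Compound 2 `COC(=O)c1c(Cl)cccc1-c1ccc([C@@H](C)Nc2nccc(Cl)c2NC(=O)CC#N)cc1`: 6.3 h

In an in vivo ADME assay on the whole organism for metabolic stability, with Canis familiaris (Canis lupus familiaris) as the target, at a dose of 1 mg/kg by the intravenous route (a lower number here means that the compound disappears faster, a higher number that the compound lasts longer), compound 1 gives 2.1 h, the lower of the two numbers at hand. Compound 2 gives 6.3 h in this assay, and the gap between the two lies beyond the scatter; since these compounds differ in more than one place, their two values say nothing about any single change. Compound 3 `C[C@@H](Nc1nccc(Cl)c1NC(=O)CC#N)c1ccc(-c2cccc(F)c2-c2nnn(C)n2)cc1` has not yet been measured. It differs from compound 1 by 2-methyl-2H-tetrazol-5-yl in place of 3-methyl-1,2,4-oxadiazol-5-yl on an aromatic carbon. Among the measured compounds shown here, no measured pair isolates this change, so there is no basis for expecting a step beyond the scatter, and the change a 1.2-fold higher number from compound 1 to compound 3 (0.08 log units; within the scatter) is expected to be small. Compound 3 is accordingly estimated at 2.5 h, within a range from 1.2 h to 5 h.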

Compound 3, half-life: 3.8 h
For compound 3 the middle estimate is 1.5-fold (0.18 log units) below the measured one, and the stated range covers the measured number.
By their numbers in this assay, from the lowest: compounds 1, 3 and 2 (each within the scatter of the next, the first and the last beyond it).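

Placed on an aromatic carbon of a six-membered aromatic ring of carbon only, ortho to a fluoro group, 2-methyl-2H-tetrazol-5-yl in place of 3-methyl-1,2,4-oxadiazol-5-yl gives the first comparison here that isolates one change: in this assay, the step is a 1.8-fold higher number from compound 1 to compound 3 (0.26 log units; within the scatter). The half-life therefore does not separate these two five-membered aromatic rings at this position, although the entering ring holds four nitrogens and the leaving ring two nitrogens and one oxygen. Compound 2 differs from both of the others in more than one place, so its steps to them cannot be read.

From the compounds shown here alone, whether a carboxylic acid, an amine or a primary amide on this same carbon would give a step beyond the scatter stays open. Nothing at hand bears on why these two rings give this result.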